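Replacing the Furan of Compound 2 with Benzimidazole

A few compounds are considered here, and "the series" means these few. Any claim that something is new, unique, unknown or untested is made for them only; others in the source may bear on it.

compound 1 `O=c1[nH]/c(=C\c2ccc(Br)o2)c(=O)[nH]/c1=C\c1cccc(Oc2ccc(F)cc2)c1` – 361 nM
compound 2 `O=c1[nH]/c(=C\c2ccc(CO)o2)c(=O)[nH]/c1=C\c1cccc(Oc2ccc(F)cc2)c1` – 41.5 nM

Of these two compounds, compound 2 gives the lower number in a functional assay on NCI-H460 cells (Homo sapiens) for cytotoxicity, read by MTT assay, with a stated time of 72 h; on this read-out lower numbers stand for stronger inhibition and higher numbers for weaker inhibition (41.5 nM). Within the data shown here, the only measured step is an 8.7-fold lower number from compound 1 to compound 2 (0.94 log units; beyond the scatter) and it came with hydroxymethyl in place of bromo on an aromatic carbon.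

The next compound to be read is compound 3 `O=c1[nH]/c(=C\c2nc3ccccc3[nH]2)c(=O)[nH]/c1=C\c1cccc(Oc2ccc(F)cc2)c1`, which carries 1H-benzimidazol-2-yl in place of 5-(hydroxymethyl)furan-2-yl on a double-bonded chain carbon bound to an aromatic carbon. Among the measured compounds shown here, no measured step covers this exchange of the whole group. The step of an 8.7-fold lower number from compound 1 to compound 2 (0.94 log units; beyond the scatter) bears on it only loosely, but it shows that a change at this end can pass the scatter. A step of modest size in this assay is therefore expected, more likely upward than downward. The estimated step is a 2.4-fold higher number from compound 2 to compound 3 (0.38 log units; beyond the scatter) and remains an expectation. The estimate for compound 3 is 100 nM (expected range 20 nM to 500 nM).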

Compound 3, half-maximal inhibitory concentration: > 1000 nM
Compound 3 gave a limit, no number (the forecaster's own chance of this, stated with the estimate: 3%); at least 10-fold (1.00 log units) between middle value and limit.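

Compound 3 gives no number, only a limit of the assay: the limit of > 1000 nM in this assay, at which 1 of the 3 values shown sits. In this assay, the earlier compounds had shown only that the group on the furan could shift the reading, whereas the exchange of the whole 5-(hydroxymethyl)furan-2-yl group for 1H-benzimidazol-2-yl gives an at least 24-fold higher number from compound 2 to compound 3 (1.38 log units; beyond the scatter). The gap also holds against the bromo compound, with an at least 2.7-fold higher number from compound 1 to compound 3 (0.44 log units; beyond the scatter), so among the three compounds shown, both furans give lower numbers than the benzimidazole at this place.

The compounds shown leave open whether the change follows from the added six-membered aromatic ring or from the different five-membered ring, as both differ at once in compound 3. They also leave open how an amine or a carboxylic acid in place of the hydroxymethyl on the furan would read in this assay.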